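A few compounds are considered here, and "the series" means these few. Any claim that something is new, unique, unknown or untested is made for them only; others in the source may bear on it.

In an ADME assay on HEK293 cells (Homo sapiens) for cytotoxicity, with a stated time of 6 h (on this read-out lower numbers stand for higher toxicity in this test and higher numbers for lower toxicity in this test), compound 1 `CCCCNc1nc(N)nc2cccc(C)c12` gives > 25000 nM as a limit, not a number. Compound 2 `CCCCNc1nc(N)nc2cccc(OCc3ccccn3)c12` gives > 25000 nM as a limit too. Compound 3 `CCCCNc1nc(N)nc2cccc(C(=O)NC)c12` also gives > 25000 nM as a limit. All three thus sit at the limit of > 25000 nM in this assay, at which 3 of the 3 values shown sit, with no exact number.

Compound 4 `CCCCNc1nc(N)nc2cccc(C(=O)NCc3ccccc3)c12` differs from compound 3 by phenyl in place of hydrogen on a saturated chain carbon bound to an amide-type nitrogen and so has phenyl in place of hydrogen on a saturated chain carbon bound to an amide-type nitrogen, turning methylamino into benzylamino. For the measured compounds named here, three measured steps bear on this: a step that the two limits leave unreadable from compound 1 to compound 2 and a step that the two limits leave unreadable from compound 1 to compound 3 and a step that the two limits leave unreadable from compound 2 to compound 3 all stay at the limit. No size can be read from them, so only a weak guide remains.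

The expected change in this assay is a step that the limit leaves unreadable from compound 3 to compound 4 with no direction expected beyond the scatter. For compound 4 the estimated value is 30000 nM within an expected range of 15000 nM to 60000 nM and most likely the assay will report only a limit again.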

Compound 4, half-maximal cytotoxic concentration: > 25000 nM
Compound 4 gave a limit, no number (the forecaster's own chance of this, stated with the estimate: 85%); the middle value is on the limit's open side.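

In this assay compound 4 gives > 25000 nM, a limit and not a number, so its step from compound 3 cannot be read. The exact toxicity of every compound shown stays open, because all of them stop at the same limit: the limit of > 25000 nM in this assay, at which 4 of the 4 values shown sit.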